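Swapping the Sulfonyl Aryl Group in Two Related Cores

The source may hold more compounds than are shown below. What is called first, only, known or untested is meant among the compounds shown, and "the series" means these compounds.

Compound 1 `O=S(=O)(c1ccc(F)c(Cl)c1)c1cnc2c(F)cccc2c1-c1cccc(Cl)c1` and compound 2 `O=S(=O)(c1ccc(F)c(Cl)c1)c1cnc2cc(F)ccc2c1-c1ccc(Cl)cc1` are built from the same atoms joined differently; the difference between the two cores is not broken down here. In an ADME assay on microsomes from liver (Homo sapiens) for metabolic stability, tested at 2.5 uM (a lower number here means slower removal, a higher number faster removal of the compound), compound 1 gives 0.18 mL/min and compound 2 gives 0.39 mL/min. Compound 3 `O=S(=O)(c1cc(F)cc(F)c1)c1cnc2c(F)cccc2c1-c1cccc(Cl)c1` comes from compound 1 through one change, (3,5-difluorophenyl in place of 3-chloro-4-fluorophenyl on a sulfonyl sulfur). In this assay compound 3 gives 0.64 mL/min. That step is a 3.6-fold higher number from compound 1 to compound 3 (0.55 log units; beyond the scatter). Compound 4 `O=S(=O)(c1cc(F)cc(F)c1)c1cnc2cc(F)ccc2c1-c1ccc(Cl)cc1` arises from compound 2 by the same change, (3,5-difluorophenyl in place of 3-chloro-4-fluorophenyl on a sulfonyl sulfur). Because the same change is already seen as a 3.6-fold higher number from compound 1 to compound 3 (0.55 log units; beyond the scatter), a similar step is expected in this assay, namely a 3.1-fold higher number from compound 2 to compound 4 (0.49 log units; beyond the scatter), although it rests on a single pair. Compound 4 is therefore estimated to give 1.2 mL/min in this assay, with a likely range from 0.5 mL/min to 2.8 mL/min.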

Compound 4, intrinsic clearance in a liver preparation (reported as CLH), per the amount of preparation that the assay uses: 0.03 mL/min
For compound 4 the middle estimate is 40-fold (1.60 log units) above the measured one; the whole stated range lies above it.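

Placing 3,5-difluorophenyl where 3-chloro-4-fluorophenyl stood on the sulfonyl sulfur gives, in this assay, a 13-fold lower number from compound 2 to compound 4 (1.11 log units; beyond the scatter). The same swap therefore does not carry over from one core to the other, and its direction reverses: the same change on two cores in this assay, a 3.6-fold higher number (0.55 log units; beyond the scatter) from compound 1 to compound 3 and a 13-fold lower number (1.11 log units; beyond the scatter) from compound 2 to compound 4, 46-fold (1.66 log units) apart, beyond the scatter of two such steps

This shows that the outcome of the swap depends on the core, but with a single pair on each core, it does not show which difference between the cores is responsible.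

As far as these compounds go, it remains open whether another group on the sulfonyl sulfur, such as an amine or a methoxy group, would also behave differently on the two cores. Any rule for predicting this swap on a further core also remains open.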